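This account rests on a few compounds, and the source may have more. Where it says the series, first, only, none or still open, it means among the compounds named here.

Of the compounds shown here, three built on one shared core have been measured in an ADME assay on microsomes from liver (Rattus norvegicus) for metabolic stability, using NADPH, with a stated time of 10 min; on this read-out higher numbers stand for a more stable compound and lower numbers for a less stable compound. Compound 1 `CN1CC[C@H]2CN(c3cccc4c3C[C@H](CN(C)[C@H]3CCCc5cccnc53)NC4)C[C@H]21` gives 1.78% in this assay. Compound 2 `CN1C[C@@H]2CN(c3cccc4c3C[C@H](CN(C)[C@H]3CCCc5cccnc53)NC4)C[C@@H]2C1` gives 35.3%, and compound 3 `CN(C)C1CCN(c2cccc3c2C[C@H](CN(C)[C@H]2CCCc4cccnc42)NC3)CC1` gives 52.4%. Among these three numbers compound 2 stands second highest: its nearest neighbour is compound 3 and its furthest is compound 1, and both gaps lie beyond the scatter, as the step of a number 33.5 percentage points higher from compound 1 to compound 2 (beyond the scatter) and the step of a number 17.1 percentage points higher from compound 2 to compound 3 (beyond the scatter) show.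

Compound 4 `CN(C[C@H]1Cc2c(cccc2N2CCC(N)CC2)CN1)[C@H]1CCCc2cccnc21` has not yet been measured. It differs from compound 2 at one place: a group of 7 heavy atoms (5 carbon, 2 nitrogen; one six-membered non-aromatic ring with 1 hetero atom) in place of a group of 9 heavy atoms (7 carbon, 2 nitrogen; 2 five-membered non-aromatic rings with 1 hetero atom each), on an aromatic carbon. The measured steps that bear on this are the two in which one six-membered non-aromatic ring takes the place of the two five-membered non-aromatic rings on an aromatic carbon, namely a number 17.1 percentage points higher from compound 2 to compound 3 (beyond the scatter) and a number 50.6 percentage points higher from compound 1 to compound 3 (beyond the scatter). Both point upward, the first modest and the second large. The group entering compound 4 is a 4-aminopiperidin-1-yl, smaller than the six-membered ring group of compound 3, and for compound 4 the expected step is upward and of modest size, a number 19.7 percentage points higher from compound 2 to compound 4 (beyond the scatter). For compound 4 the expected value in this assay is 55%, with a range from 35% to 75%.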

Compound 4, percent of the compound remaining: 38.4%
The estimate for compound 4 lay 16.6 percentage points above the measured number, within the range that was stated.
By their numbers in this assay, from the lowest: compound 1; then compounds 2 and 4 (each within the scatter of the next); then compound 3.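

Replacing the two-ring group of compound 2 with 4-aminopiperidin-1-yl gives a number 3.1 percentage points higher from compound 2 to compound 4 (within the scatter) in this assay and so the two compounds cannot be told apart, which shows that a single six-membered ring on this aromatic carbon does not by itself secure a higher number than compound 2 gives. For the compounds shown here, what hangs on that ring also counts, a point the earlier compounds could not show: with the ring kept and only its substituent changed, the result is a number 14 percentage points lower from compound 3 to compound 4 (beyond the scatter) and so the dimethylamino group of compound 3 and the amino group of compound 4 are not interchangeable here. The large gap to the least stable compound of the series also holds for this new group, at a number 36.6 percentage points higher from compound 1 to compound 4 (beyond the scatter) and so it now appears with three different groups at this place.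

On these data alone, whether a methylamino group, a longer chain ending in an amine or a carboxylic acid on the same ring carbon would give a number nearer that of compound 3 or that of compound 4 remains open. Nothing shown here explains why these numbers differ.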